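Swapping the aryl group: from dimethoxyphenyl to fluorophenyl

The source may report more compounds than this note shows. Statements on the series, on what has been measured and on what is new or still open speak of the compounds shown alone.

Measured so far:
Compound 1 `COc1ccc(/C=C2\CC[C@H]3C(C)(C)CCC[C@]3(C)[C@H]2CCC(C)CC(=O)O)cc1` gives a limit rather than a number in a functional assay on THP-1 cells (Homo sapiens) for cytotoxicity, read by MTT assay, with a stated time of 72 h (on this read-out lower numbers stand for stronger inhibition and higher numbers for weaker inhibition), namely > 200000 nM.
Compound 2 `COc1ccc(/C=C2\CC[C@H]3C(C)(C)CCC[C@]3(C)[C@H]2CCC(C)CC(=O)O)cc1OC` gives in this assay a value of 106000 nM.

Within the data shown here, compound 2 thus holds the only real number in this assay; the other entry is a limit of the assay (the limit of > 200000 nM in this assay, at which 1 of the 2 values shown sits). Among the measured compounds shown here, the single measured step, an at least 1.8-fold lower number from compound 1 to compound 2 (0.27 log units; that floor lies within the scatter), rests on that limit, so its size is only a floor and it falls within the scatter.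

Compound 3 `CC(CC[C@H]1/C(=C/c2ccc(F)cc2)CC[C@H]2C(C)(C)CCC[C@]12C)CC(=O)O` has not been measured. It differs from compound 2 by 4-fluorophenyl in place of 3,4-dimethoxyphenyl on a double-bonded chain carbon bound to a double-bonded ring carbon. The step from compound 1 to compound 2 bears on it only loosely: it concerns one methoxy gained, whereas here both methoxy groups leave and a fluorine enters. With so little to go on, the expected outcome is a change of the same modest order or none beyond the scatter, leaning toward a higher number since compound 1, which has fewer methoxy groups, sits at the limit. The estimated step is a 1.7-fold higher number from compound 2 to compound 3 (0.23 log units; within the scatter). For compound 3 the expected value in this assay is 180000 nM, ranging from 70000 nM to 450000 nM.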

Compound 3, half-maximal inhibitory concentration: > 200000 nM
Compound 3: a limit, no number (the forecaster's own chance of this, stated with the estimate: 45%); middle value at least 1.1-fold (0.04 log units) away from the limit.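

In this assay, putting 4-fluorophenyl in place of 3,4-dimethoxyphenyl on the double-bonded chain carbon gives an at least 1.8-fold higher number from compound 2 to compound 3 (0.27 log units; that floor lies within the scatter). As far as these compounds go, this size is only a floor, so the true distance between the two compounds stays unknown, and the data do not show a real loss on this swap. What is new is that an aryl group with fluorine and no methoxy also ends at the limit, which leaves compound 2 as the only one of the three with a real number, and compounds 1 and 3 both limits, so the step between them cannot be read: the limit of > 200000 nM in this assay, at which 2 of the 3 values shown sit.

From the compounds shown here alone, compound 3 changes two things at once, losing both methoxy groups and gaining a fluorine, so the effect of each alone remains open, and a phenyl ring carrying one methoxy and one fluorine would be needed to separate them. Going by these compounds, it also remains open whether any other group at this place, such as an amine or a nitrile on the phenyl ring, would give a clearly lower number than compound 2 shows.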